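A few compounds are considered here, and "the series" means these few. Any claim that something is new, unique, unknown or untested is made for them only; others in the source may bear on it.

Compounds 1, 2 and 3 share one core and differ only in the group on a saturated chain carbon bound to an amide-type nitrogen in a ring. Compound 1 `Cc1noc(C)c1-c1ccc2c(c1)C(c1ccccc1)N(Cc1nnc(-c3ccccc3)o1)C(=O)N2C` carries a 5-phenyl-1,3,4-oxadiazol-2-yl there, and in a functional assay on MCF7 cells (Homo sapiens) for inhibition, read by MTT assay, with a stated time of 48 h, tested at 2 uM (a higher number here means more inhibition at the concentration tested (going by the name of the read-out), a lower number less inhibition), compound 1 gives 34.1%. Compound 2 `Cc1noc(C)c1-c1ccc2c(c1)C(c1ccccc1)N(Cc1nnc(-c3ccccc3)s1)C(=O)N2C` carries a 5-phenyl-1,3,4-thiadiazol-2-yl instead, and in this assay compound 2 gives 35.7%. Compound 3 `Cc1noc(C)c1-c1ccc2c(c1)C(c1ccccc1)N(Cc1nc(-c3ccccc3)cs1)C(=O)N2C` carries a 4-phenyl-1,3-thiazol-2-yl, and in this assay compound 3 gives 29.1%, the lowest of the three numbers, although the gaps a number 5 percentage points lower from compound 1 to compound 3 (within the scatter) and a number 6.6 percentage points lower from compound 2 to compound 3 (within the scatter) are both within the scatter, as is a number 1.6 percentage points higher from compound 1 to compound 2 (within the scatter).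

Compound 4 `Cc1noc(C)c1-c1ccc2c(c1)C(c1ccccc1)N(Cc1nc(-c3ccc(F)cc3)cs1)C(=O)N2C` differs from compound 3 by fluoro in place of hydrogen on an aromatic carbon. Among the compounds with values here, none of the measured steps involves a fluoro, so no step bears on this change directly. The three measured steps each exchange the whole heterocycle on that chain carbon, and every one of them stays within the scatter; a change of a single atom on an aromatic carbon is therefore expected to move this assay by no more than the scatter, with no direction favoured. Compound 4 is estimated to give 29% in this assay, between 19% and 39%, which corresponds to an expected step of a number 0.1 percentage points lower from compound 3 to compound 4 (within the scatter).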

Compound 4, a percentage reported as inhibition, at one concentration (the size of the read-out at that concentration, not a potency): 27.4%
Estimate against measurement, compound 4: 1.6 percentage points above, within the range that was stated.
By their numbers in this assay, from the lowest: compounds 4, 3, 1 and 2 (each within the scatter of the next).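

Within the data shown here, the change from hydrogen to fluoro on an aromatic carbon, para to a large group, is the first measured change on the outer phenyl ring rather than in the heterocycle, and in this assay it gives a number 1.7 percentage points lower from compound 3 to compound 4 (within the scatter). Changing that heterocycle and adding the fluoro in one exchange also stays inside the usual variation, with a number 8.3 percentage points lower from compound 2 to compound 4 (within the scatter) and a number 6.7 percentage points lower from compound 1 to compound 4 (within the scatter), so this assay separates none of the four compounds at the single concentration tested and shows no effect of this fluoro on the 4-phenyl-1,3-thiazol-2-yl group. Nothing available offers an explanation for this flat result.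

The compounds shown leave open whether a different group at this same place on the phenyl ring, such as an amine or a carboxylic acid, would shift the number beyond the usual variation. They also leave open whether the same fluoro would behave in the same way on the phenyl ring of the 5-phenyl-1,3,4-oxadiazol-2-yl or 5-phenyl-1,3,4-thiadiazol-2-yl group.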